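The compounds below may be only part of what the source reports. "The series", "measured", "known", "first", "only" and "open" are said of these compounds alone.

Measured so far:

compound 1, `O=c1[nH]c(=O)n(COC(CO)CO)cc1O` — > 100000 nM
compound 2, `O=C(CCl)Nc1c[nH]c(=O)[nH]c1=O` — 17000 nM
compound 3, `O=C(CCl)Nc1cn(COC(CO)CO)c(=O)[nH]c1=O` — 18000 nM

In a functional assay on MIA PaCa-2 cells (Homo sapiens) for inhibition, read by MTT assay, with a stated time of 72 h (on this read-out lower numbers stand for stronger inhibition and higher numbers for weaker inhibition), compound 1 gives only a limit of the assay, > 100000 nM, and no number. Compound 2 gives 17000 nM in this assay. Compound 3 gives 18000 nM, the highest of the two numbers; its nearest neighbour is compound 2, and the two sit within the usual scatter of each other.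

Compound 4, `O=c1ccn(COC(CO)CO)c(=O)[nH]1`, has not yet been measured. It differs from compound 3 in one place: hydrogen in place of ((chloromethyl)carbonyl)amino on an aromatic carbon.

Among the measured compounds shown here, one measured step bears on this change: an at least 5.5-fold lower number from compound 1 to compound 3 (0.74 log units; beyond the scatter). That step put the ((chloromethyl)carbonyl)amino group in and lowered the number; compound 1 itself, without it, gave only a limit (the limit of > 100000 nM in this assay, at which 1 of the 3 values shown sits). Taking the group out again, as in compound 4, is therefore expected to raise the number in this assay by a sizeable step, a 5.6-fold higher number from compound 3 to compound 4 (0.74 log units; beyond the scatter), quite possibly back to a limit. Compound 4 is estimated at 100000 nM, with a range from 30000 nM to 300000 nM.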

Compound 4, half-maximal inhibitory concentration: > 100000 nM
Compound 4: no number, only a limit (the forecaster's own chance of this, stated with the estimate: 60%); the middle value sits exactly at the limit.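

In this assay, putting hydrogen in place of ((chloromethyl)carbonyl)amino gives an at least 5.5-fold higher number from compound 3 to compound 4 (0.74 log units; beyond the scatter). Until now this position had been compared only with hydroxy, so the hydroxy of compound 1 might have been what kept that compound at its limit, but with hydrogen there the shared core again gives no number, and the measurable inhibition of compound 3 goes with the ((chloromethyl)carbonyl)amino group itself: the limit of > 100000 nM in this assay, at which 2 of the 4 values shown sit. The step from compound 1 to compound 4 cannot be read, since both values are limits, so hydroxy and hydrogen cannot be ranked against each other.

Which part of the group matters stays open, since a plain acetyl amide without the chlorine, or a simple amine, would separate the chlorine from the amide. A longer chain carrying the chlorine is equally untested here.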